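A Hydroxyphenyl Variant in a Paw Edema Inhibition Series

A few compounds are considered here, and "the series" means these few. Any claim that something is new, unique, unknown or untested is made for them only; others in the source may bear on it.

Three compounds have been measured in a functional assay on the whole organism for inhibition, with Rattus norvegicus as the target, read by paw edema, with stated times of 30 min and 3 h, at a dose of 10 mg/kg by the oral route; a lower number here means less inhibition, a higher number more inhibition at the dose given (going by the name of the read-out):
compound 1 `COc1ccc(C2CC(C3C(=O)c4ccccc4C3=O)=NC(=O)N2)cc1` gives 22%;
compound 2 `O=C1N=C(C2C(=O)c3ccccc3C2=O)CC(c2ccc([N+](=O)[O-])cc2)N1` gives 19%;
compound 3 `O=C1N=C(C2C(=O)c3ccccc3C2=O)CC(c2ccc(Cl)cc2)N1` gives 31%.

Compound 3 stands highest of the three numbers. Its nearest neighbour is compound 1, with a number 9 percentage points higher from compound 1 to compound 3 (within the scatter), a step within the scatter; the furthest is compound 2, with a number 12 percentage points higher from compound 2 to compound 3 (beyond the scatter), a step beyond the scatter but modest. Between the other two lies a number 3 percentage points lower from compound 1 to compound 2 (within the scatter), also within the scatter.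

Compound 4 `O=C1N=C(C2C(=O)c3ccccc3C2=O)CC(c2ccccc2O)N1` has not yet been measured in this assay. 2-hydroxyphenyl in place of 4-chlorophenyl on a saturated ring carbon Each of the three measured steps exchanges the group on that same aromatic ring, and none of them moves the number far: two lie within the scatter and one is modest, the widest being a number 12 percentage points higher from compound 2 to compound 3 (beyond the scatter). Within the data shown here, none of the measured steps involves a hydroxy group or a 2-substituted ring, so the present change is covered only loosely. Compound 4 is therefore expected to sit near compound 3, with a step of a number 8 percentage points lower from compound 3 to compound 4 (within the scatter) expected, at most a slight downward lean and quite possibly none beyond the scatter. Compound 4 is estimated at 23%, with a range from 10% to 36%.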

Compound 4, a percentage reported as inhibition, in the whole organism at one dose (the size of the read-out at that dose, not a potency): 19%
Compound 4: the middle estimate sits 4 percentage points above what was measured, within the range that was stated.
By their numbers in this assay, from the lowest: compounds 2, 4, 1 and 3 (each within the scatter of the next, the first and the last beyond it).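

In this assay, among these compounds, placing 2-hydroxyphenyl on the saturated ring carbon in place of 4-chlorophenyl gives a number 12 percentage points lower from compound 3 to compound 4 (beyond the scatter), the first step here that brings in a hydroxy group and a 2-substituted ring. Set against the other two groups, the same position gives no change at the digits printed from compound 2 to compound 4 (within the scatter) and a number 3 percentage points lower from compound 1 to compound 4 (within the scatter), so 2-hydroxyphenyl reads alongside 4-nitrophenyl and 4-methoxyphenyl, and only compound 3 stands clear of compound 4. Nothing available offers a cause for these steps.

The compounds shown do not separate the effect of the hydroxy group from that of its place on the ring. From the compounds shown here alone, it also remains open how an aminophenyl group or a phenyl ring bearing a carboxylic acid would read in this assay at this position.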